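Shared-core series: tolerance readings and one estimate

This account rests on a few compounds, and the source may have more. Where it says the series, first, only, none or still open, it means among the compounds named here.

Measured so far:
compound 1 `Fc1cccc(NC(=S)OCCc2ccccn2)c1` — in an ADME assay on MT4 cells (Homo sapiens) for cytotoxicity, read by MTT assay (a lower number here means that less compound is tolerated, a higher number that more compound is tolerated), compound 1 returns >= 100000 nM
compound 2 `FC(F)(F)c1ccc(NC(=S)OCCc2ccccn2)cc1` — in this assay compound 2 returns 50000 nM

The value of compound 1 is a limit of the measurement and not a number, see (the limit of >= 100000 nM in this assay, at which 1 of the 2 values shown sits). For the measured compounds named here, compound 2 carries the only number in the set, the other entry being a limit, so no order between the two can be stated.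

Compound 3 `CN(C)c1ccc(NC(=S)OCCc2ccccn2)cc1` is not yet measured. It differs from compound 2 by dimethylamino in place of trifluoromethyl on an aromatic carbon, in words dimethylamino in place of trifluoromethyl on an aromatic carbon. Going by the values given here, no step between two measured compounds is available to calibrate such a change, so the expectation rests on the two readings alone. The expected step is a 1.4-fold higher number from compound 2 to compound 3 (0.15 log units; within the scatter), small and probably within the scatter, if anything toward more compound tolerated. In this assay compound 3 is expected to give 70000 nM, with a range from 30000 nM to 150000 nM. A limit readout rather than a number is a real possibility for compound 3.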

Compound 3, half-maximal cytotoxic concentration: 60000 nM
Compound 3: middle estimate off by 1.2-fold (0.07 log units), on the high side; the range from low to high includes it.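

In this assay, the first step measured between two compounds that differ in one place is a 1.2-fold higher number from compound 2 to compound 3 (0.08 log units; within the scatter), so the two readings cannot be told apart. The position concerned is an aromatic carbon of a six-membered aromatic ring of carbon only, para to a large group, and it accepts either trifluoromethyl or dimethylamino with no separable difference in this assay, even though the two groups differ in their atoms and dimethylamino counts as a hydrogen-bond acceptor while trifluoromethyl does not. This holds only for compound 2 and compound 3 and sets no trend for other groups at this position.

From the compounds shown here alone, whether any other group here, such as a carboxylic acid, a primary amine or a longer alkyl chain, would move the reading beyond the scatter remains open. Compound 1 also differs from the other two in more than one place and carries a limit rather than a number, so it gives no calibration for this position: the limit of >= 100000 nM in this assay, at which 1 of the 3 values shown sits.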